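A few compounds are considered here, and "the series" means these few. Any claim that something is new, unique, unknown or untested is made for them only; others in the source may bear on it.

Compound 1 `NCCCc1ccc(-c2ccc(-c3ccc(-c4cccs4)s3)s2)s1` was run in an ADME assay on MDCK cells (Canis lupus familiaris) for cytotoxicity, read by MTT assay, with a stated time of 2 days; on this read-out lower numbers stand for higher toxicity in this test and higher numbers for lower toxicity in this test. In this assay compound 1 gives > 200000 nM, which is a limit of the assay rather than a measured number. Compound 2 `NCCCc1ccc(-c2ccc(-c3ccc(CCCN)s3)s2)s1` differs from it by 3-aminopropyl in place of thiophen-2-yl on an aromatic carbon. In this assay compound 2 also gives > 200000 nM, again a limit. The step that the two limits leave unreadable from compound 1 to compound 2 thus cannot be read, because both ends rest on (the limit of > 200000 nM in this assay, at which 2 of the 3 values shown sit). Compound 3 `BrCCCCc1ccc(CCCCBr)s1` has no result in this assay: compound 3 gives "not determined" (no result reported).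

Compound 4 `BrCCCc1ccc(-c2ccc(-c3ccc(-c4cccs4)s3)s2)s1` has not been measured. It differs from compound 1 by bromo in place of amino on a saturated chain carbon, three bonds along the chain from an aromatic carbon. Among the compounds with values here, no measured step touches this change, and the single step available is unreadable, so nothing here points to a movement in this assay in either direction. Compound 4 is therefore expected to give about 200000 nM, between 100000 nM and 400000 nM, an expected step of a number no higher from compound 1 to compound 4 (the limit leaves the size open) that would stay within the scatter, most likely again reported only as a limit.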

Compound 4, half-maximal cytotoxic concentration: > 200000 nM
Compound 4 was reported as a limit; the forecaster's own chance of this, stated with the estimate: 75%; the middle value sits exactly at the limit.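

Within the data shown here, compound 1 and compound 4 both rest on a limit of the assay, so no step between them can be read: the limit of > 200000 nM in this assay, at which 3 of the 4 values shown sit. The compounds shown leave open whether bromo in place of amino changes the result in this assay at all.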